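Hydroxymethyl for hydroxy on a thiazole chain carbon

The source may hold more compounds than are shown below. What is called first, only, known or untested is meant among the compounds shown, and "the series" means these compounds.

Measured in an ADME assay on MT2 cells (Homo sapiens) for cytotoxicity, read by XTT assay, with a stated time of 4 days; on this read-out higher numbers stand for lower toxicity in this test and lower numbers for higher toxicity in this test:
compound 1 `Cc1nc(C(NC(=O)C(=O)Nc2ccc(Cl)cc2)C2CCCN2)sc1CO` gives 45000 nM
compound 2 `Cc1nc(C(NC(=O)C(=O)Nc2ccc(Cl)cc2)C2CCCN2)sc1CCO` gives 42000 nM
compound 3 `Cc1nc(C(NC(=O)C(=O)Nc2ccc(F)cc2)C2CCCCN2)sc1CO` gives > 113000 nM

For compound 3 the value in this assay is a limit of the assay, not a number (the limit of > 113000 nM in this assay, at which 1 of the 3 values shown sits).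

Among the measured compounds shown here, the one measured step is a 1.1-fold lower number from compound 1 to compound 2 (0.03 log units; within the scatter), the change being (hydroxymethyl in place of hydroxy on a saturated chain carbon bound to an aromatic carbon). Compound 4 `Cc1nc(C(NC(=O)C(=O)Nc2ccc(F)cc2)C2CCCCN2)sc1CCO` is not yet measured and differs from compound 3 by hydroxymethyl in place of hydroxy on a saturated chain carbon bound to an aromatic carbon: the same change at the same place. How the core of compound 1 differs from the core of compound 3 is not broken down here.

In this assay the expected step that the limit leaves unreadable from compound 3 to compound 4 rests on the measured 1.1-fold lower number from compound 1 to compound 2 (0.03 log units; within the scatter), which stayed within the scatter. Compound 4 is estimated at 120000 nM, with a range from 55000 nM to 260000 nM, and a limit rather than a number is thought likely.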

Compound 4, half-maximal cytotoxic concentration: 109000 nM
Compound 4: the middle estimate sits 1.1-fold (0.04 log units) above what was measured; the measured number falls inside the stated range.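

In this assay, the change from hydroxymethyl to 2-hydroxyethyl on the second core gives an at least 1.0-fold lower number from compound 3 to compound 4 (0.01 log units; that floor lies within the scatter), and the comparison with the first core reads: the same change on two cores in this assay, a 1.1-fold lower number (0.03 log units; within the scatter) from compound 1 to compound 2 and an at least 1.0-fold lower number (0.01 log units; that floor lies within the scatter) from compound 3 to compound 4; the limit leaves it open whether they differ

Compound 3 stands at a limit of the assay, > 113000 nM, and this is not a number. The pair on the core of compound 3 is therefore compatible with the small step on the core of compound 1 carrying over, but it does not show that the step has the same size on both cores, and a larger step on the core of compound 3 remains possible.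

The compounds shown leave open what a longer chain, such as 3-hydroxypropyl, or an amine or a carboxylic acid in place of the 2-hydroxyethyl would give. They also leave open how this change behaves on any other core.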